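The source may hold more compounds than are shown below. What is called first, only, known or untested is meant among the compounds shown, and "the series" means these compounds.

In a functional assay on HepG2 cells (Homo sapiens) for antiproliferative activity, read by MTT assay, with a stated time of 48 h (on this read-out higher numbers stand for weaker inhibition and lower numbers for stronger inhibition), compound 1 `CCOc1ccccc1-n1nncc1CN1C(=O)C2(C(C#N)=C(N)Oc3c2c2nc4ccccc4nc2c2ccccc32)c2ccccc21` gives only a limit, > 50000 nM. Compound 2 `N#CC1=C(N)Oc2c(c3nc4ccccc4nc3c3ccccc23)C12C(=O)N(Cc1cnnn1-c1ccc(N)cc1)c1ccccc12` likewise reaches only a limit in this assay, > 50000 nM. The step between them, a step that the two limits leave unreadable from compound 1 to compound 2, cannot be read, since both values sit at the limit of > 50000 nM in this assay, at which 2 of the 2 values shown sit. Compound 3 `Cc1ccc(C)c(-n2nncc2CN2C(=O)C3(C(C#N)=C(N)Oc4c3c3nc5ccccc5nc3c3ccccc43)c3ccccc32)c1` has not yet been measured in this assay; it differs from compound 2 by 2,5-dimethylphenyl in place of 4-aminophenyl on an aromatic nitrogen. Among the measured compounds shown here, the only measured step that touches this position of the shared core, from compound 1 to compound 2, is unreadable, so no size can be assigned to a change of the aryl group on the aromatic nitrogen. Compound 2 stands at the limit of this assay, with no number behind it. It is therefore expected that compound 3 also remains at the limit, and its value in this assay is estimated as 50000 nM, between 15000 nM and 200000 nM, with an expected step from compound 2 of a number no higher from compound 2 to compound 3 (the limit leaves the size open) that should lie within the scatter.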

Compound 3, half-maximal inhibitory concentration: > 50000 nM
Compound 3 gave a limit, no number; the forecaster's own chance of this, stated with the estimate: 85%; the middle value sits exactly at the limit.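

In this assay compound 3 gives only a limit, > 50000 nM. Among the compounds shown here, no step among compound 1, compound 2 and compound 3 can therefore be read: the limit of > 50000 nM in this assay, at which 3 of the 3 values shown sit. The compounds shown leave open whether changing the aryl group on the aromatic nitrogen alters antiproliferative activity at all.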